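A few compounds are considered here, and "the series" means these few. Any claim that something is new, unique, unknown or untested is made for them only; others in the source may bear on it.

Of the compounds shown here, three with a shared core have been measured in a physicochemical assay for lipophilicity, read by HPLC; on this read-out higher numbers stand for higher lipophilicity and lower numbers for lower lipophilicity. Compound 1, `CCC(=O)N1CC[C@H](Oc2ncnc3c2nc(-c2cnc(C)nc2)n3CC)C1`, carries a propanoyl group on the ring nitrogen of its pyrrolidine and gives 0.8. Compound 3, `CCn1c(-c2cnc(C)nc2)nc2c(N[C@H]3CCN(C(=O)N4CC(OC)C4)C3)ncnc21`, gives 0.7, a number that lies within the scatter of the value for compound 1, so the two cannot be told apart on this read-out. Compound 2, `CCn1c(-c2ccc(C(F)(F)F)nc2)nc2c(O[C@H]3CCN(C(=O)C4CCOC4)C3)ncnc21`, gives 1.9, which sits well beyond the scatter above compound 1. Among the three numbers, compound 1 thus stands second highest, close to compound 3 and far below compound 2.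

Compound 4, `CCn1c(-c2cnc(C)nc2)nc2c(O[C@H]3CCN(C(=O)C4CC(F)(F)C4)C3)ncnc21`, has not yet been measured. It differs from compound 1 in one place: 3,3-difluorocyclobutyl in place of ethyl on a carbonyl carbon. Among the compounds with values here, no pair of measured compounds differs in just this one place, so there is no measured step to lean on. Within the data shown here, the only footing is the value of compound 1 and the fact that a larger carbon group bearing two fluorines enters where an ethyl left.

On that footing, compound 4 is expected to land higher than compound 1, with an expected step from compound 1 to compound 4 of a number 0.60 log units higher from compound 1 to compound 4 (beyond the scatter), beyond the scatter. The estimate for compound 4 is 1.4, with a range from 1 to 1.9.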

Compound 4, distribution coefficient: 1.5
Compound 4: the middle estimate sits 0.10 log units below what was measured, and the stated range covers the measured number.
By their numbers in this assay, from the lowest: compounds 3 and 1 (each within the scatter of the next); then compound 4; then compound 2.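

Within the data shown here, compound 1 and compound 4 give the first measured step in this set that comes from a change in one place: in this assay, putting 3,3-difluorocyclobutyl in place of ethyl on the carbonyl carbon gives a number 0.70 log units higher from compound 1 to compound 4 (beyond the scatter). This shows that the read-out responds to the group held on this carbonyl carbon, whose other neighbour is an amide-type nitrogen in a ring, with the rest of compound 1 unchanged. No measurement at hand explains the rise.

The change brings in more carbon atoms, a four-membered ring and two fluorines all at once, and the compounds shown leave open which of these accounts for the step; plain cyclobutyl on the same carbonyl carbon would set the ring apart from the fluorines. Also open, going by these compounds, is how the read-out would move with a group of another kind at this place, such as a longer carbon chain or a chain ending in an amine.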